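Returning to a Thiophene Sulfonylurea Against Lymphoma Cells

The source may hold more compounds than are shown below. What is called first, only, known or untested is meant among the compounds shown, and "the series" means these compounds.

Among the compounds with values here, compound 3 `CCc1ccc(S(=O)(=O)NC(=O)Nc2ccc(Cl)cc2)[nH]1` was tested in a functional assay on the whole organism (6C3HED cells, Mus musculus) for inhibition, at a dose of 300 mg/kg by the oral route (a lower number here means less inhibition, a higher number more inhibition at the dose given (going by the name of the read-out)), where compound 3 gives 56%, the lowest of the three numbers measured so far. Compound 1 `O=C(Nc1ccc(Cl)cc1)NS(=O)(=O)c1cccs1` gives 66%, and compound 2 `CCc1ccc(S(=O)(=O)NC(=O)Nc2ccc(Cl)cc2)s1` gives 89%. Compound 4 `Cc1ccsc1S(=O)(=O)NC(=O)Nc1ccc(Cl)cc1` differs from compound 3 in one place: 3-methylthiophen-2-yl in place of 5-ethyl-1H-pyrrol-2-yl on a sulfonyl sulfur. Within the data shown here, two measured steps bear on this change. Replacing the ethyl-bearing thiophene by the ethyl-bearing pyrrole gave a number 33 percentage points lower from compound 2 to compound 3 (beyond the scatter), whereas the same swap without the ethyl gave a number 10 percentage points lower from compound 1 to compound 3 (within the scatter), which is within the usual scatter. Returning to a thiophene, now carrying a methyl, is therefore expected to lift the number by a modest step, a number 19 percentage points higher from compound 3 to compound 4 (beyond the scatter). For compound 4 the estimate is 75%, with a likely range from 55% to 92%.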

Compound 4, a percentage reported as inhibition, in the whole organism at one dose (the size of the read-out at that dose, not a potency): 62%
The estimate for compound 4 lay 13 percentage points above the measured number; the measured number falls inside the stated range.
By their numbers in this assay, from the lowest: compounds 3, 4 and 1 (each within the scatter of the next); then compound 2.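

In this assay, the 3-methylthiophen-2-yl group does not carry the gain seen with 5-ethylthiophen-2-yl, giving a number 27 percentage points lower from compound 2 to compound 4 (beyond the scatter), while the methyl on the plain thiophene leaves a number 4 percentage points lower from compound 1 to compound 4 (within the scatter). Going back to a thiophene from 5-ethyl-1H-pyrrol-2-yl brings no clear gain either, with a number 6 percentage points higher from compound 3 to compound 4 (within the scatter). No measurement here explains why the methyl and ethyl thiophenes differ. On these data alone, the two groups differ in both chain and place on the ring, so it remains open which of these decides the outcome. As far as these compounds go, how a propyl chain or an amine on the thiophene would fare also remains open.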